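The compounds below may be only part of what the source reports. "The series", "measured", "known", "first", "only" and "open" are said of these compounds alone.

Compound 1 `N#Cc1ccc(C(=O)Nc2cccc(NC(=O)COc3ccc4c(=O)ccoc4c3)c2)cc1`: 123 nM
Compound 2 `Cc1cc(C(=O)Nc2cccc(NC(=O)COc3ccc4c(=O)ccoc4c3)c2)no1`: 68 nM

In an assay on isolated protein for inhibition of Rho-associated protein kinase 1 (Homo sapiens), read by scintillation counting, radiometric assay and 33P incorporation, with a stated time of 40 min, in the presence of a further agent that is not named here (on this read-out higher numbers stand for weaker inhibition and lower numbers for stronger inhibition), compound 2 holds the lower of the two numbers, with compound 1 nearest, as the step of a 1.8-fold lower number from compound 1 to compound 2 (0.26 log units; within the scatter) shows. Compound 3 `O=C(COc1ccc2c(=O)ccoc2c1)Nc1cccc(NC(=O)c2ccc(C(=O)O)cc2)c1` differs from compound 2 by 4-carboxyphenyl in place of 5-methyl-1,2-oxazol-3-yl on a carbonyl carbon. Within the data shown here, the one step that bears on this is a 1.8-fold lower number from compound 1 to compound 2 (0.26 log units; within the scatter), where a six-membered aromatic ring of carbon only also stood in place of the 5-methyl-1,2-oxazol-3-yl, and it lay within the scatter. Compound 3 is therefore expected to give a somewhat higher number, by a 1.8-fold higher number from compound 2 to compound 3 (0.25 log units; within the scatter), a step within the scatter. The estimate for compound 3 is 120 nM, with a range from 50 nM to 300 nM.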

Compound 3, half-maximal inhibitory concentration: 6890 nM
Compound 3: middle estimate off by 57-fold (1.76 log units), on the low side; measured number outside the range, above it.
By their numbers in this assay, from the lowest: compounds 2 and 1 (each within the scatter of the next); then compound 3.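

In this assay, the place on the carbonyl carbon proves sensitive to what sits there: 4-carboxyphenyl in place of 5-methyl-1,2-oxazol-3-yl gives a 100-fold higher number from compound 2 to compound 3 (2.01 log units; beyond the scatter). Carboxy in place of cyano on an aromatic carbon, with the rest unchanged, gives a 56-fold higher number from compound 1 to compound 3 (1.75 log units; beyond the scatter), so this one exchange on the ring is enough for a large step, unlike the earlier exchange of whole rings. Nothing at hand explains why this exchange costs so much. The compounds shown leave open whether a methyl ester or a primary carboxamide in place of the carboxy would stay close to compound 1 or fall with compound 3.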